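The source may report more compounds than this note shows. Statements on the series, on what has been measured and on what is new or still open speak of the compounds shown alone.

Compound 1 `COc1cc(NC(C)CCCNC(=O)Nc2cccc(F)c2)c2ncccc2c1` is the starting point: in a functional assay on SW-620 cells (Homo sapiens) for inhibition, read by MTT assay, with a stated time of 72 h (on this read-out lower numbers stand for stronger inhibition and higher numbers for weaker inhibition), compound 1 gives 27000 nM. Compound 3 `COc1cc(NC(C)CCCNC(=O)Nc2cccc(C(F)(F)F)c2)c2ncccc2c1` differs from compound 1 by one change, (trifluoromethyl in place of fluoro on an aromatic carbon). In this assay compound 3 gives 22000 nM, a step of a 1.2-fold lower number from compound 1 to compound 3 (0.09 log units; within the scatter). Compound 2 `COc1cc(NC(C)CCCNC(=O)NNC(=O)Nc2cccc(F)c2)c2ncccc2c1` carries a different core, and how it differs from compound 1 is ((3-fluorophenyl)carbamoyl)amino in place of 3-fluorophenyl on an amide-type nitrogen. In this assay compound 2 gives 9500 nM, a step of a 2.8-fold lower number from compound 1 to compound 2 (0.45 log units; beyond the scatter). Compound 4 `COc1cc(NC(C)CCCNC(=O)NNC(=O)Nc2cccc(C(F)(F)F)c2)c2ncccc2c1` has not yet been measured; it relates to compound 2 as compound 3 relates to compound 1, through (trifluoromethyl in place of fluoro on an aromatic carbon), and the place of the change is the same in both pairs. Because the earlier step of a 1.2-fold lower number from compound 1 to compound 3 (0.09 log units; within the scatter) stayed within scatter, the step to compound 4 is expected to be about a 1.2-fold lower number from compound 2 to compound 4 (0.07 log units; within the scatter). Compound 4 is therefore estimated at 8000 nM, between 4000 nM and 17000 nM.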

Compound 4, half-maximal inhibitory concentration: 21000 nM
Compound 4: middle estimate off by 2.6-fold (0.42 log units), on the low side, and the stated range ends below it.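

In this assay, trifluoromethyl in place of fluoro gives a 2.2-fold higher number from compound 2 to compound 4 (0.34 log units; beyond the scatter), so the gain in strength seen on moving to the core of compound 2 is not kept with this group. The change therefore does not carry over unchanged from the core of compound 1 to the core of compound 2, as the two steps differ: the same change on two cores in this assay, a 1.2-fold lower number (0.09 log units; within the scatter) from compound 1 to compound 3 and a 2.2-fold higher number (0.34 log units; beyond the scatter) from compound 2 to compound 4, 2.7-fold (0.43 log units) apart, beyond the scatter of two such steps This rests on just two pairs of compounds, so it shows that the result of this change depends on the core here, but not why, nor how any other group would behave.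

Still open, going by these compounds, is whether a chloro or methoxy group on the same aromatic carbon would also behave differently on the two cores. A shorter chain in place of the present one is also untested among the compounds shown.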